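This account rests on a few compounds, and the source may have more. Where it says the series, first, only, none or still open, it means among the compounds named here.

Compound 1 `NNC(=O)c1c(NC(=O)NS(=O)(=O)c2ccccc2)sc2c1CCCCC2`: in a functional assay on EKVX cells (Homo sapiens) for inhibition, with a stated time of 48 h (a higher number here means a weaker inhibitor of growth, a lower number a stronger inhibitor of growth), compound 1 gives > 100000 nM, which is a limit of the assay and not a number. Compound 2 `O=C(Nc1sc2c(c1C(=O)NNc1ccccc1)CCCCC2)NS(=O)(=O)c1ccccc1`: in this assay compound 2 gives > 100000 nM, again a limit. Compound 3 `CN1CCN(C(=O)c2c(NC(=O)NS(=O)(=O)c3ccccc3)sc3c2CCCCC3)CC1`: in this assay compound 3 gives > 100000 nM, also a limit.

Compound 3 thus stands at a limit, as do the other two, and all three share the same point: the limit of > 100000 nM in this assay, at which 3 of the 3 values shown sit. The measured steps a step that the two limits leave unreadable from compound 1 to compound 2, a step that the two limits leave unreadable from compound 1 to compound 3 and a step that the two limits leave unreadable from compound 2 to compound 3 are consequently of unreadable size, each running from one limit to another. Compound 4 `O=C(Nc1sc2c(c1C(=O)NNc1ccc(Br)cc1)CCCCC2)NS(=O)(=O)c1ccccc1` has not yet been measured. It differs from compound 3 by ((4-bromophenyl)amino)amino in place of 4-methylpiperazin-1-yl on a carbonyl carbon. The closest comparison among the measured steps is a step that the two limits leave unreadable from compound 2 to compound 3, compound 2 carrying an anilinoamino group on the same carbonyl carbon where compound 4 carries ((4-bromophenyl)amino)amino; that step gave no readable size. Compound 4 is therefore expected to sit at the limit as well, with an estimated value of 100000 nM in this assay, ranging from 30000 nM to 300000 nM. The step this expectation implies, a number no higher from compound 3 to compound 4 (the limit leaves the size open), is expected to remain unreadable against the limit.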

Compound 4, concentration for 50% growth inhibition: > 100000 nM
Compound 4: a limit, no number (the forecaster's own chance of this, stated with the estimate: 85%); the middle value lies on the limit itself.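

In this assay, for the compounds shown here, compound 4 gives > 100000 nM, which is a limit and not a number, and no step joining compound 1, compound 2, compound 3 and compound 4 can be read: the limit of > 100000 nM in this assay, at which 4 of the 4 values shown sit. None of these compounds gives a number, which leaves open how the groups on the carbonyl carbon rank against one another.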